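The source may report more compounds than this note shows. Statements on the series, on what has been measured and on what is new or still open speak of the compounds shown alone.

In an ADME assay on J774.A1 cells (Mus musculus) for cytotoxicity, read by MTT assay, with a stated time of 72 h (a higher number here means that more compound is needed for the effect, a lower number that less compound is needed), the measured compounds are:

compound 1 `CC(C)Nc1nc(NCc2ccco2)c2ccccc2n1`: 17000 nM
compound 2 `CC(C)Nc1nc(NCc2ccco2)c2ccc(Cl)cc2n1`: > 100000 nM, a limit of the assay
compound 3 `Cc1ccc2c(NCc3ccco3)nc(NC(C)C)nc2c1`: > 33000 nM, a limit of the assay

Compound 3 thus stands only at a limit in this assay, with no number of its own, and compound 2 likewise gives only a limit. Compound 4 `COc1ccc2c(NCc3ccco3)nc(NC(C)C)nc2c1` differs from compound 3 by methoxy in place of methyl on an aromatic carbon. The measured steps that touch the same place are an at least 1.9-fold higher number from compound 1 to compound 3 (0.28 log units; that floor lies within the scatter) and a step that the two limits leave unreadable from compound 2 to compound 3; neither tells what a methoxy group does there, and the steps read so far give no sign of a large shift. A step of no clear size is expected from compound 3 to compound 4, namely an at least 1.1-fold lower number from compound 3 to compound 4 (0.04 log units; that floor lies within the scatter). Compound 4 is therefore estimated at 30000 nM, between 8000 nM and 100000 nM.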

Compound 4, half-maximal effective concentration: 16000 nM
Compound 4: the middle estimate sits 1.9-fold (0.27 log units) above what was measured; low and high end bracket the measured number.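

In this assay, among these compounds, methoxy is the one group on this aromatic carbon that gives a measured number rather than a limit, and that number stays level with the hydrogen of the shared core: a 1.1-fold lower number from compound 1 to compound 4 (0.03 log units; within the scatter). Methoxy also parts from the other two groups, giving an at least 2.0-fold lower number from compound 3 to compound 4 (0.31 log units; beyond the scatter) and an at least 6.2-fold lower number from compound 2 to compound 4 (0.79 log units; beyond the scatter). Both of these steps start from a limit of the assay, so they are floors only.

Going by these compounds, how far compound 2 and compound 3 truly lie from compound 4 stays open. Also open, on these data alone, is whether an amine, a carboxylic acid or a longer chain such as ethoxy on this carbon would follow methoxy or chloro.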